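The source may report more compounds than this note shows. Statements on the series, on what has been measured and on what is new or still open speak of the compounds shown alone.

Of the compounds shown here, two have been read so far in an in vitro ADME assay on microsomes from liver (Homo sapiens) for metabolic stability, tested at 5 uM (on this read-out higher numbers stand for a longer-lived compound and lower numbers for a shorter-lived compound), and neither gives an exact half-life. Compound 1 (`CS(=O)(=O)Nc1ccc2c(c1)S(=O)(=O)N=C(c1c(O)c(-c3ccc(Cl)s3)nn(CCC3CC3)c1=O)N2`) gives > 1 h, which is a limit of the assay and not a number. Compound 2 (`CC(C)(C)CCn1nc(-c2cccs2)c(O)c(C2=NS(=O)(=O)c3cc(NS(C)(=O)=O)ccc3N2)c1=O`) gives > 1 h, which is also a limit and not a number. Among the compounds with values here, the whole picture in this assay is therefore (the limit of > 1 h in this assay, at which 2 of the 2 values shown sit), and compound 2 stands at that limit with no measured step to any other compound.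

Compound 3 (`CCC(C)(C)Cn1nc(-c2cccs2)c(O)c(C2=NS(=O)(=O)c3cc(NS(C)(=O)=O)ccc3N2)c1=O`) keeps the shared core of compound 2 and has the same atoms, joined differently: 1,1-dimethylpropyl in place of neopentyl on a saturated chain carbon bound to an aromatic nitrogen. The change puts 1,1-dimethylpropyl in place of neopentyl on a saturated chain carbon bound to an aromatic nitrogen. Within the data shown here, no measured step gives a size for this change, so no shift beyond the usual scatter is expected in this assay, in either direction. This expectation rests on compound 2, with its limit of > 1 h. The estimated change is a step that the limit leaves unreadable from compound 2 to compound 3. For compound 3 the expected half-life is 1.2 h, with an estimated range of 0.6 h to 2.4 h.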

Compound 3, half-life: > 1 h
Compound 3 was reported as a limit; the forecaster's own chance of this, stated with the estimate: 75%; the middle value is on the limit's open side.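

In this assay, within the data shown here, compound 3 and compound 2 are both reported only as limits and not as numbers, so no step between them can be read. The same holds for every compound shown: the limit of > 1 h in this assay, at which 3 of the 3 values shown sit. The compounds shown leave open the exact half-life of each one, and whether 1,1-dimethylpropyl in place of neopentyl changes it at all.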